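Urea series on the shared core: cell growth inhibition

The source may hold more compounds than are shown below. What is called first, only, known or untested is meant among the compounds shown, and "the series" means these compounds.

Measured so far:
Compound 1 `O=C(Nc1cccc(-n2cc(-c3ccncc3)c(-c3ccc(Cl)c(O)c3)n2)c1)Nc1ccc(Cl)c(Cl)c1`: > 32500 nM
Compound 2 `COc1cc(-c2nn(-c3cccc(NC(=O)c4ccccc4)c3)cc2-c2ccncc2)ccc1Cl`: > 100000 nM

In a functional assay on NCI-H226 cells (Homo sapiens) for inhibition, read by sulforhodamine B assay, with a stated time of 48 h (on this read-out lower numbers stand for stronger inhibition of growth and higher numbers for weaker inhibition of growth), compound 1 gives > 32500 nM, which is a limit of the assay and not a number. Compound 2, the benzamide, gives > 100000 nM, again a limit and not a number. Compound 1 therefore stands at the limit of > 32500 nM in this assay, at which 1 of the 2 values shown sits, and no number for it is known; the other value shown sits at the limit of > 100000 nM in this assay, at which 1 of the 2 values shown sits. Among the measured compounds shown here, no step between two measured compounds can be drawn from this pair.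

Compound 3 `O=C(Nc1cccc(-n2cc(-c3ccncc3)c(-c3ccc(Cl)c(O)c3)n2)c1)Nc1ccc(Cl)c(C(F)(F)F)c1` differs from compound 1 by trifluoromethyl in place of chloro on an aromatic carbon. The change sits on an aromatic carbon of a six-membered aromatic ring of carbon only, ortho to a chloro group and meta to a large group; one bond further out it reads 3,4-dichlorophenyl to 4-chloro-3-(trifluoromethyl)phenyl.

With compound 1 reporting only a limit, no step beyond the scatter is expected in this assay. The expected step that the limit leaves unreadable from compound 1 to compound 3 is none beyond the usual scatter. Compound 3 is expected at 45000 nM, range 15000 nM to 150000 nM, most likely again reported as a limit.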

Compound 3, concentration for total growth inhibition: > 32500 nM
Compound 3: a limit, no number; the forecaster's own chance of this, stated with the estimate: 75%; the middle value is on the limit's open side.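

In this assay compound 3 gives > 32500 nM, a limit and not a number. Among the compounds shown here, compound 1 also reports only a limit, so no step between compound 1 and compound 3 can be read. The compounds shown leave open how trifluoromethyl and chloro compare here, and whether any compound on the shared core gives a number in this assay.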